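A few compounds are considered here, and "the series" means these few. Any claim that something is new, unique, unknown or untested is made for them only; others in the source may bear on it.

Measured in a functional assay on MES-SA cells (Homo sapiens) for inhibition, read by fluorescence, with a stated time of 72 h; a higher number here means a weaker inhibitor, a lower number a stronger inhibitor:
- compound 1 `CCc1ccc(/C=N/NC(=S)Nc2ccc(OC)cc2)nc1`: 96 nM
- compound 2 `O=[N+]([O-])c1ccc(NC(=S)N/N=C/c2ccccn2)cc1`: 2690 nM; 2740 nM (2 entries)

Compound 1 gives 96 nM, the only number shown for it, and one further entry for compound 1 carries no single number. Of the two measured compounds, it has the lower value and so is the stronger inhibitor in this assay, while the readings for compound 2 agree closely.

The next compound, compound 3 `CCc1ccc(/C=N/NC(=S)Nc2ccc([N+](=O)[O-])cc2)nc1`, keeps the core of compound 1 and places nitro in place of methoxy on an aromatic carbon, para to a large group: nitro in place of methoxy on an aromatic carbon.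

Going by the values given here, no measured pair isolates this change. Compound 2 also carries a nitro group and gives 2690 nM; 2740 nM (2 entries), but it differs from compound 1 in more than one place, so only part of that gap can be expected to carry over. A clear step toward weaker inhibition, beyond the scatter, is therefore expected in this assay, though a smaller one than the gap between the two measured compounds. The expected change is a 4.2-fold higher number from compound 1 to compound 3 (0.62 log units; beyond the scatter). For compound 3 the estimated value is 400 nM, with an expected range from 110 nM to 1500 nM.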

Compound 3, half-maximal inhibitory concentration: 10500 nM
Estimate against measurement, compound 3: 26-fold (1.42 log units) below; measured number outside the range, above it.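

In this assay, putting nitro in place of methoxy on an aromatic carbon, para to a large group, gives a 110-fold higher number from compound 1 to compound 3 (2.04 log units; beyond the scatter), so this position on the shared core is far from indifferent to the group it carries. Going by these compounds alone, until now no measured pair had isolated a change at this place; this pair is the first, and it ties a large loss of inhibition to this single exchange, with the rest of the core of compound 1 unchanged. The step is also far wider than the spread between repeat readings of one compound in this assay, so it cannot be put down to scatter: the several entries of compound 2 in this assay, 2690 nM; 2740 nM (2 entries)

The step rests on a single pair, so it cannot tell whether the loss belongs to nitro itself or would follow any departure from methoxy at this position. On these data alone, how an amine, a chlorine atom or a longer chain such as ethoxy would read at this place stays open, as does whether the same exchange would cost as much on another core.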